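The source may report more compounds than this note shows. Statements on the series, on what has been measured and on what is new or still open speak of the compounds shown alone.

Notes on the series built on the shared core of compound 1 `COCCOCCOc1cccc2ccc(N)nc12`. In an assay on cells with melanin-concentrating hormone receptor 1 (Homo sapiens) as the target, read by radioligand binding (a higher number here means a weaker inhibitor, a lower number a stronger inhibitor), compound 1 gives only a limit of the assay, > 2000 nM, and so stands at the upper edge of the numbers shown (the limit of > 2000 nM in this assay, at which 1 of the 3 values shown sits). Compound 2 `Nc1ccc2cccc(OCCC(F)(F)F)c2n1` gives 722 nM in this assay, and compound 3 `CCOCC(C)Oc1cccc2ccc(N)nc12` gives 1070 nM. The exchange of 2-methoxyethoxy for trifluoromethyl reads an at least 2.7-fold lower number from compound 1 to compound 2 (0.44 log units; beyond the scatter); the next step reads a 1.5-fold higher number from compound 2 to compound 3 (0.17 log units; within the scatter). Compound 4 `CCOCCOc1cccc2ccc(N)nc12` differs from compound 1 by hydrogen in place of methoxy on a saturated chain carbon, two bonds along the chain from an oxygen on a saturated carbon, read more broadly as 2-methoxyethoxy to ethoxy. Both measured steps bear only loosely on it: one starts from a limit, the other stays within the scatter. A modest fall in number is expected, an at least 1.3-fold lower number from compound 1 to compound 4 (0.12 log units; that floor lies within the scatter). For compound 4 the estimate in this assay is 1500 nM, with a range of 600 nM to 5000 nM.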

Compound 4, half-maximal inhibitory concentration: > 2000 nM
Compound 4: no number, only a limit; the forecaster's own chance of this, stated with the estimate: 35%; middle value at least 1.3-fold (0.12 log units) from the limit.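

In this assay, compound 4 joins compound 1 at a limit of the assay, not a number: the limit of > 2000 nM in this assay, at which 2 of the 4 values shown sit.

The step between those two limits cannot be read, so losing the methoxy brings no readable gain at this position. Ethoxy in place of trifluoromethyl reads an at least 2.7-fold higher number from compound 2 to compound 4 (0.44 log units; beyond the scatter), and hydrogen in place of methyl on the chain carbon reads an at least 1.8-fold higher number from compound 3 to compound 4 (0.27 log units; that floor lies within the scatter).

As far as these compounds go, how far compound 1 and compound 4 lie beyond the limit stays open. Also open, from the compounds shown here alone, is how an amine or a carboxylic acid at the chain end, or a longer fluorinated chain, would read.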